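A few compounds are considered here, and "the series" means these few. Any claim that something is new, unique, unknown or untested is made for them only; others in the source may bear on it.

Compound 1 `COc1ccc(-c2ccc3c(NCCCNCc4cccc(OC)c4O)ccnc3c2)cc1`: 32000 nM
Compound 2 `CC(C)(C)c1ccc(Oc2ccc3c(NCCCNCc4ccco4)ccnc3c2)cc1`: 14500 nM

Of these two, compound 1 stands higher in a physicochemical assay for solubility, with a stated time of 18 h, at pH 7.4; a lower number here means a less soluble compound, a higher number a more soluble compound; compound 2 gives a lower value, a gap beyond the scatter. Compound 3 `COc1cccc(Oc2ccc3c(NCCCNCc4cccc(OC)c4O)ccnc3c2)c1` has not yet been measured in this assay. It differs from compound 1 in one place: 3-methoxyphenoxy in place of 4-methoxyphenyl on an aromatic carbon. For the measured compounds named here, no step between measured compounds covers this change, and compound 2 differs from both in a second place as well, so only a loose expectation is possible. The step from compound 1 to compound 3 is expected to be small, likely within the scatter, as a 1.3-fold lower number from compound 1 to compound 3 (0.11 log units; within the scatter). Compound 3 is therefore estimated at 25000 nM, with a range from 8000 nM to 60000 nM.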

Compound 3, solubility: 14500 nM
Estimate against measurement, compound 3: 1.7-fold (0.24 log units) above, within the range that was stated.
By their numbers in this assay, from the lowest: compounds 2 and 3 (each within the scatter of the next); then compound 1.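

In this assay, for the compounds shown here, the exchange of 4-methoxyphenyl for 3-methoxyphenoxy on this aromatic carbon gives a 2.2-fold lower number from compound 1 to compound 3 (0.34 log units; beyond the scatter) and so shows that this position responds to the change, which the earlier compounds could not show. The change moves the methoxy group and adds an oxygen in the same step, and the result cannot tell these two apart. Nothing measured here accounts for the step. Open, as far as these compounds go, is how 3-methoxyphenyl or 4-methoxyphenoxy would read at this position, which would separate the two parts of the change. Also open, from the compounds shown here alone, is what a carboxylic acid or an amine on the same ring would do.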